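The source may report more compounds than this note shows. Statements on the series, on what has been measured and on what is new or still open speak of the compounds shown alone.

Of the compounds shown here, three of one series have been tested in a functional assay on the whole organism (strain NMRI) with Mus musculus as the target, in the maximal electroshock model, with a stated time of 4 h; a lower number here means that less compound is needed, a higher number that more compound is needed for the effect. Compound 1 `O=[N+]([O-])c1ccc(Cn2cc(CO/N=C/c3c(-c4ccc(F)cc4)nc4ccc(Br)cn34)nn2)cc1` gives 100 mg/kg and stands at the highest of the three numbers. Compound 2 `Cc1ccc(-c2nc3c(C)cccn3c2/C=N/OCc2cn(Cc3ccc([N+](=O)[O-])cc3)nn2)cc1` gives 40 mg/kg, a number lower than that of compound 1 by a margin beyond the usual scatter. Compound 3 `COc1ccc(Cn2cc(CO/N=C/c3c(-c4ccccc4)nc4c(C)cccn34)nn2)cc1` gives 40 mg/kg, set apart from compound 1 by the same margin. Compound 2 and compound 3 sit at the same number, so nothing separates them. Among the compounds with values here, no pair among the three differs in a single place, since the cores and the benzyl substituents change together, so no isolated step can be read from the measured set.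

Compound 4 `O=[N+]([O-])c1ccc(Cn2cc(CO/N=C/c3c(-c4ccccc4)nc4ccc(Br)cn34)nn2)cc1` is the next candidate and differs from compound 1 in one place: hydrogen in place of fluoro on an aromatic carbon. Cut one bond further out, the change reads 4-fluorophenyl to phenyl. Compound 3 also carries phenyl rather than 4-fluorophenyl and shows the lower number, yet it differs from compound 1 in other places too, so it cannot settle the matter. Within the data shown here, with no measured step of this kind to lean on, the expected step is no change at the digits printed from compound 1 to compound 4 (within the scatter), which is not expected to reach beyond the scatter in this assay. The estimate for compound 4 is 100 mg/kg, within the range 40 mg/kg to 250 mg/kg.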

Compound 4, minimum effective dose: 40 mg/kg
The estimate for compound 4 lay 2.5-fold (0.40 log units) above the measured number; the measured number falls inside the stated range.
By their numbers in this assay, from the lowest: compounds 2, 3 and 4 (each within the scatter of the next); then compound 1.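

In this assay, the series now holds its first step that can be read in isolation: a 2.5-fold lower number from compound 1 to compound 4 (0.40 log units; beyond the scatter). Only hydrogen in place of fluoro on an aromatic carbon separates the pair, para to a large group, so in this pair the 4-fluorophenyl form needs more compound for the effect than the phenyl form, and the fluoro is not required for activity in this model. Nothing in the available data accounts for the size or direction of this step.

This is a single pair on a single background, and whether the same change would give a similar step on the cores of compound 2 or compound 3 cannot be read from the compounds shown. On these data alone, it also remains open how other groups at this place, such as chloro, a dimethylamino group or a carboxylic acid, would compare with hydrogen and fluoro, so the data show one change at this position rather than a trend across substituents.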